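Chloro to methyl on the aryl ring of compound 1

The source may report more compounds than this note shows. Statements on the series, on what has been measured and on what is new or still open speak of the compounds shown alone.

Three compounds have a result in an ADME assay on HEL cells (Homo sapiens) for cytotoxicity, read by microscopy; a higher number here means that more compound is tolerated, a lower number that less compound is tolerated:

Compound 1, `O=c1ccn(CCCCCOc2ccc(Cl)cc2)c(=O)[nH]1`, gives only a limit of the assay, > 100000 nM.
Compound 2, `Cc1cn(CCCCCOc2ccc(Br)cc2)c(=O)[nH]c1=O`, gives 100000 nM.
Compound 3, `O=c1ccn(CCCCCCOc2ccc(Br)cc2)c(=O)[nH]1`, gives 20000 nM.

Compound 1 stands at the limit of > 100000 nM in this assay, at which 1 of the 3 values shown sits. Its value is a limit of the assay and not a number, so it can only be said that no cytotoxicity was seen up to that concentration. Compounds 2 and 3 carry a bromo group in place of the chloro and differ from compound 1 in other parts of the chain or the core as well, so nothing is known about a single step among the measured compounds.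

Compound 4, `Cc1ccc(OCCCCCn2ccc(=O)[nH]c2=O)cc1`, has not yet been measured. It differs from compound 1 by methyl in place of chloro on an aromatic carbon. The change is a swap of one heavy atom for another at the same place, with no ring, donor or acceptor added or removed.

Among the compounds with values here, with no measured step to lean on, the step in this assay from compound 1 to compound 4 is expected to be none beyond the scatter, with cytotoxicity again appearing only at a high concentration or not at all; the expected step of a number no higher from compound 1 to compound 4 (the limit leaves the size open) reflects this. Compound 4 is therefore estimated at 100000 nM, within a range from 30000 nM to 200000 nM.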

Compound 4, minimum cytotoxic concentration: 100000 nM
Compound 4: the middle estimate sits on the measured number at the digits printed; the measured number falls inside the stated range.
By their numbers in this assay, from the lowest: compound 3; then compounds 2 and 4 (each within the scatter of the next).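

This is the first change in a single place among the compounds shown, and it puts a measured number on this position of the aromatic ring: in this assay, compound 4, which carries the 4-methylphenyl group, gives 100000 nM. Compound 1, which carries the 4-chlorophenyl group, gives > 100000 nM, and this is a limit of the assay and not a number. The swap of one heavy atom for another therefore reads as a number no higher from compound 1 to compound 4 (the limit leaves the size open), and its size cannot be read because one end of the step is a limit: the limit of > 100000 nM in this assay, at which 1 of the 4 values shown sits.

The compounds shown leave open how other groups at this place on the aromatic ring, such as an amine, a methoxy group or a carboxylic acid, would fare in this assay. They also leave open whether methyl in place of chloro would give a readable step on a longer chain, where the comparison might not run into the limit of the assay.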